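A few compounds are considered here, and "the series" means these few. Any claim that something is new, unique, unknown or untested is made for them only; others in the source may bear on it.

Measured compounds and their values in a functional assay on HT cells (Homo sapiens) for antiproliferative activity, read by fluorescence, with a stated time of 72 h; on this read-out lower numbers stand for stronger inhibition of growth and higher numbers for weaker inhibition of growth:
compound 1 `CC(C)c1n[nH]c2c(NCc3ccc(-c4ccccn4)cc3)nc(SCC(O)CN)nc12` gives 55 nM
compound 2 `CC(O)CSc1nc(NCc2ccc(-c3ccccn3)cc2)c2[nH]nc(C(C)C)c2n1` gives 62 nM
compound 3 `CC(C)c1n[nH]c2c(NCc3ccc(-c4ccccn4)cc3)nc(SC3CCCC3O)nc12` gives 567 nM

Compound 3 stands highest of the three numbers. The two open-chain hydroxyalkyl thioethers sit close together: a 1.1-fold higher number from compound 1 to compound 2 (0.05 log units; within the scatter). Against them the cyclic analogue falls clearly back: a 9.1-fold higher number from compound 2 to compound 3 (0.96 log units; beyond the scatter) and a 10-fold higher number from compound 1 to compound 3 (1.01 log units; beyond the scatter), both beyond the scatter.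

Compound 4 `CC(C)c1n[nH]c2c(NCc3ccc(-c4ccccn4)cc3)nc(SCCCO)nc12` differs from compound 3 in one place: 3-hydroxypropyl in place of 2-hydroxycyclopentyl on a sulfur. The exchange is the reverse of the one already seen, a five-membered carbon ring carrying a hydroxyl giving way to a hydroxyalkyl chain on the same sulfur. Among the measured compounds shown here, the steps that bear on it are those from compound 2 and compound 1 to compound 3; both run upward beyond the scatter, so in reverse a drop of comparable size is expected for compound 4. The 3-hydroxypropyl chain is not identical to the 2-hydroxypropyl chain of compound 2, so part of the recovery may be lost, and the expected step is accordingly set slightly short of a full return: a 6.7-fold lower number from compound 3 to compound 4 (0.82 log units; beyond the scatter). Compound 4 is therefore estimated at 85 nM, with a range from 35 nM to 220 nM.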

Compound 4, concentration for 50% growth inhibition: 109 nM
For compound 4 the middle estimate is 1.3-fold (0.11 log units) below the measured one, and the stated range covers the measured number.
By their numbers in this assay, from the lowest: compounds 1, 2 and 4 (each within the scatter of the next); then compound 3.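

In this assay, a hydroxyalkyl chain on the sulfur in place of the ring brings a clear change, a 5.2-fold lower number from compound 3 to compound 4 (0.72 log units; beyond the scatter), so among the compounds shown the 2-hydroxycyclopentyl group of compound 3 stands alone and all three open-chain thioethers form one group. That group tolerates a different placing of the hydroxyl, with a 1.8-fold higher number from compound 2 to compound 4 (0.25 log units; within the scatter), and also the absence of the amino group, with a 2.0-fold higher number from compound 1 to compound 4 (0.30 log units; within the scatter), so neither the branched hydroxyl arrangement nor the amine on the chain is needed at this position to stay within the scatter of compound 1 and compound 2. No measurement at hand bears on why the ring carries this cost.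

The compounds shown cannot separate the effect of the ring itself from that of the hydroxyl placed on it, which an unsubstituted cyclopentyl group or a 3-hydroxycyclopentyl group on the same sulfur would address. On these data alone, how far the chain tolerance extends also stays open, including whether the hydroxyl is needed at all, as a plain propyl chain, a longer 4-hydroxybutyl chain or a terminal carboxylic acid would show.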